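Second fluoro on compound 3: expected step

The source may report more compounds than this note shows. Statements on the series, on what has been measured and on what is new or still open speak of the compounds shown alone.

In a functional assay on MCF7 cells (Homo sapiens) for inhibition, in the absence of a further agent (on this read-out lower numbers stand for stronger inhibition and higher numbers for weaker inhibition), compound 3 (`Nc1ccc(-c2cc(=O)c3c(N)c(F)ccc3o2)cc1`) gives 4.4 nM and compound 2 (`Nc1ccc(-c2cc(=O)c3c(N)ccc(F)c3o2)cc1`) gives 6.9 nM within the scatter of compound 3. Compound 1 (`Nc1ccc(-c2cc(=O)c3c(N)c(F)cc(F)c3o2)cc1F`) gives 1.2 nM and so lies lower than compound 3 by more than the scatter.

Compound 4 (`Nc1ccc(-c2cc(=O)c3c(N)c(F)cc(F)c3o2)cc1`) differs from compound 3 by fluoro in place of hydrogen on an aromatic carbon with fluoro in place of hydrogen on an aromatic carbon, para to an amino group. Within the data shown here, no measured pair isolates this change. Among the measured compounds shown here, a small move toward a lower number is expected, probably not beyond the scatter, and the value of compound 1 at 1.2 nM shows only that such low numbers occur. The expected step is a 1.8-fold lower number from compound 3 to compound 4 (0.25 log units; within the scatter) as an estimate. For compound 4 the estimated value is 2.5 nM with an expected range from 0.9 nM to 7 nM in this read-out.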

Compound 4, half-maximal inhibitory concentration: 6 nM
The estimate for compound 4 lay 2.4-fold (0.38 log units) below the measured number, within the range that was stated.
By their numbers in this assay, from the lowest: compound 1; then compounds 3, 4 and 2 (each within the scatter of the next).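

In this assay, fluoro in place of hydrogen on the aromatic carbon para to an amino group gives a 1.4-fold higher number from compound 3 to compound 4 (0.13 log units; within the scatter) and the other fluoro on the shared core gives a 1.2-fold lower number from compound 2 to compound 4 (0.06 log units; within the scatter) so neither single addition moves the number beyond the scatter. Among these compounds, the one step here beyond the scatter is a 5.0-fold higher number from compound 1 to compound 4 (0.70 log units; beyond the scatter) and it removes the fluoro that compound 1 alone carries, outside the shared core. Nothing measured here explains these steps.

Going by these compounds, whether chloro, methoxy or a nitrile on that same carbon would read differently stays open. So does whether the extra fluoro of compound 1 would give a similar step without the two fluoro groups on the core.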